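This account rests on a few compounds, and the source may have more. Where it says the series, first, only, none or still open, it means among the compounds named here.

Going by the values given here, in a functional assay, read by fluorescence and spectrophotometry, with a stated time of 1 h (a higher number here means that more compound is needed for the effect, a lower number that less compound is needed), compound 1 (`O=S(=O)(/C=C/c1ccc(O)c(O)c1)CCCCCCCCO`) gives 6700 nM and compound 2 (`O=S(=O)(/C=C/c1ccc(O)c(O)c1)CCCc1ccccc1`) gives 11500 nM, so compound 2 stands within the scatter of its only measured neighbour. Compound 3 (`CCCCCCCCCCS(=O)(=O)/C=C/c1ccc(O)c(O)c1`) differs from compound 2 by heptyl in place of phenyl on a saturated chain carbon, three bonds along the chain from a sulfonyl sulfur. Among the compounds with values here, the only measured step at this place, phenyl in place of 5-hydroxypentyl, is a 1.7-fold higher number from compound 1 to compound 2 (0.23 log units; within the scatter), so no step beyond the scatter is expected in this assay. The expected step is a 1.4-fold lower number from compound 2 to compound 3 (0.16 log units; within the scatter). For compound 3 the estimate is 8000 nM, with a range of 3500 nM to 18000 nM.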

Compound 3, half-maximal effective concentration: 6800 nM
Beside the measured number, compound 3's estimate is 1.2-fold (0.07 log units) above it; the measured number falls inside the stated range.
By their numbers in this assay, from the lowest: compounds 1, 3 and 2 (each within the scatter of the next).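

In this assay, heptyl in place of phenyl, on a saturated chain carbon, three bonds along the chain from a sulfonyl sulfur, gives a 1.7-fold lower number from compound 2 to compound 3 (0.23 log units; within the scatter), so here an open chain replaces the six-membered aromatic ring without a step beyond the scatter. Ethyl in place of hydroxy, eight bonds along the chain from a sulfonyl sulfur, gives a 1.0-fold higher number from compound 1 to compound 3 (0.01 log units; within the scatter), again no step beyond the scatter. Nothing on hand accounts for these results. On these data alone, whether an amine, a carboxylic acid or a longer chain at these places would give a step beyond the scatter remains open.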